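Working notes: from compound 3 to compound 4

The source may report more compounds than this note shows. Statements on the series, on what has been measured and on what is new or still open speak of the compounds shown alone.

Values in a functional assay on a cell-free system (plasma, Oryctolagus cuniculus) for inhibition, with stated times of 5 min, 1 min and 6 min (a higher number here means a weaker inhibitor, a lower number a stronger inhibitor), so far
- compound 1 `CCOC(=O)COn1c(-c2cccc(C#N)c2)nc(C)c1C(=O)OCC` gives 6800 nM
- compound 2 `CCOC(=O)c1c(C)nc(-c2cccc(C#N)c2)n1OCc1ccncc1` gives 6200 nM
- compound 3 `CCOC(=O)c1c(C)nc(-c2cccc(C#N)c2)n1OCc1ccc(C)cc1` gives 6310 nM
- compound 4 `CCOC(=O)c1c(C)nc(-c2cccc(C#N)c2)n1OCc1cccc(C#N)c1` is not yet measured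

Compound 3 at 6310 nM lies within the scatter of both other measured compounds. Compound 4 differs from it as follows (3-cyanophenyl in place of 4-methylphenyl on a saturated chain carbon bound to an oxygen on an aromatic ring) with 3-cyanophenyl in place of 4-methylphenyl on a saturated chain carbon bound to an oxygen on an aromatic ring. Three measured replacements at this place bear on the change (a 1.1-fold lower number from compound 1 to compound 2 (0.04 log units; within the scatter) and a 1.1-fold lower number from compound 1 to compound 3 (0.03 log units; within the scatter) and a 1.0-fold higher number from compound 2 to compound 3 (0.01 log units; within the scatter)) and all lie within the scatter. None of them tests 3-cyanophenyl itself. No step beyond the scatter is therefore expected in this assay and the expected step is small (a 1.1-fold lower number from compound 3 to compound 4 (0.02 log units; within the scatter)). Compound 4 is estimated at 6000 nM with an expected range of 3000 nM to 12000 nM in this read-out.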

Compound 4, half-maximal inhibitory concentration: > 30000 nM
Compound 4 was reported as a limit; the forecaster's own chance of this, stated with the estimate: 5%; middle value at least 5.0-fold (0.69 log units) away from the limit.
By their numbers in this assay, from the lowest: compounds 2, 3 and 1 (each within the scatter of the next). At a limit, above all of these: compound 4.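

In this assay the place on a saturated chain carbon bound to an oxygen on an aromatic ring proves sensitive to the group it carries: ethoxycarbonyl, pyridin-4-yl and 4-methylphenyl read alike, but 3-cyanophenyl does not (an at least 4.7-fold higher number from compound 3 to compound 4 (0.67 log units; beyond the scatter); an at least 4.8-fold higher number from compound 2 to compound 4 (0.68 log units; beyond the scatter); an at least 4.4-fold higher number from compound 1 to compound 4 (0.64 log units; beyond the scatter)). The value of compound 4 (> 30000 nM) is a limit of the assay.

Open, on these data alone, is whether the nitrile itself or its ring position drives this step. A 4-cyanophenyl, a 3-methylphenyl or an unsubstituted phenyl at this place would separate the two, and the compounds shown include none of them.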